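The source may hold more compounds than are shown below. What is called first, only, known or untested is meant among the compounds shown, and "the series" means these compounds.

Among the measured compounds shown here, compound 2 `O=C(Nc1cccc(-c2oc3cc(-c4ccc(F)cc4)ccc3c(=O)c2O)c1)c1cc(F)cc(F)c1` gives 2070 nM in a functional assay on HCC1937 cells (Homo sapiens) for antiproliferative activity, read by CCK-8 assay, with a stated time of 72 h (on this read-out higher numbers stand for weaker inhibition and lower numbers for stronger inhibition), the lowest of the two numbers known so far; compound 1 `COc1ccc(C(=O)Nc2cccc(-c3oc4cc(-c5ccc(F)cc5)ccc4c(=O)c3O)c2)cc1` gives 5490 nM. For the measured compounds named here, that pair forms the only measured step, a 2.7-fold lower number from compound 1 to compound 2 (0.42 log units; beyond the scatter), with 3,5-difluorophenyl in place of 4-methoxyphenyl on a carbonyl carbon. Compound 3 `O=C(Nc1cccc(-c2oc3cc(-c4ccc(F)cc4)ccc3c(=O)c2O)c1)c1ccc(-c2ccccc2)cc1` carries 4-phenylphenyl in place of 3,5-difluorophenyl on a carbonyl carbon. Going by the values given here, the one measured step swaps different groups on the carbonyl carbon, so it offers little guidance for this change, and no direction can be read from it. Compound 3 is expected to give about 2000 nM, between 700 nM and 6000 nM, a step of a 1.0-fold lower number from compound 2 to compound 3 (0.01 log units; within the scatter) that stays within the scatter.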

Compound 3, half-maximal inhibitory concentration: 44100 nM
Compound 3: middle estimate off by 22-fold (1.34 log units), on the low side; measured number outside the range, above it.
By their numbers in this assay, from the lowest: compound 2; then compound 1; then compound 3.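

In this assay, the group on this carbonyl carbon can shift the number far more than the earlier pair showed: 4-phenylphenyl in place of 3,5-difluorophenyl gives a 21-fold higher number from compound 2 to compound 3 (1.33 log units; beyond the scatter). Phenyl in place of methoxy on an aromatic carbon gives an 8.0-fold higher number from compound 1 to compound 3 (0.90 log units; beyond the scatter), so compound 3 has the highest number of the three. Nothing available explains this loss of activity.

From the compounds shown here alone, it remains open whether a single phenyl ring carrying an amine or a carboxylic acid would give a number closer to compound 2 or to compound 3.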